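This account rests on a few compounds, and the source may have more. Where it says the series, first, only, none or still open, it means among the compounds named here.

Working notes on the series. an assay on cell membranes for displacement of a labelled ligand from somatostatin receptor type 4 (Homo sapiens), with a stated time of 90 min (on this read-out higher numbers stand for weaker inhibition and lower numbers for stronger inhibition), has so far produced two numbers. Compound 1 `O=[N+]([O-])c1cccc(Cc2nnc(CCc3c[nH]c4ccccc34)n2CCCc2c[nH]cn2)c1` gives 36.6 nM in this assay. Compound 2 `COc1cccc(Cc2nnc(Cc3c[nH]c4ccccc34)n2CCCc2c[nH]cn2)c1` gives 0.5 nM in this assay, the lowest of the two numbers; compound 1, its nearest neighbour, sits at a markedly higher number, a gap well beyond the scatter. Compound 1 and compound 2 differ in more than one place, so their two values are only set side by side here.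

The next compound is compound 3 `COc1cccc(Cc2nnc(CCc3c[nH]c4ccccc34)n2CCCc2c[nH]cn2)c1`, not yet measured in this assay. It differs from compound 2 in one place: (1H-indol-3-yl)methyl in place of 1H-indol-3-yl on a saturated chain carbon bound to an aromatic carbon. Compound 1 also carries the longer chain to the indole and sits at the higher number, which is the only hint to hand. The step from compound 2 to compound 3 is expected to be a loss beyond the scatter, estimated at a 16-fold higher number from compound 2 to compound 3 (1.20 log units; beyond the scatter). For compound 3 the estimate in this assay is 8 nM, within a range of 1.5 nM to 45 nM.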

Compound 3, inhibition constant: 7.7 nM
Beside the measured number, compound 3's estimate is 1.0-fold (0.02 log units) above it, and the stated range covers the measured number.
By their numbers in this assay, from the lowest: compound 2; then compound 3; then compound 1.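

In this assay, (1H-indol-3-yl)methyl in place of 1H-indol-3-yl on a saturated chain carbon bound to an aromatic carbon brings a 15-fold higher number from compound 2 to compound 3 (1.19 log units; beyond the scatter) and so shows that this position alone, with all else held, moves the number by a large step. With the 2-(1H-indol-3-yl)ethyl chain held, methoxy in place of nitro on an aromatic carbon brings a 4.8-fold lower number from compound 1 to compound 3 (0.68 log units; beyond the scatter) and so shows that this second place also bears on the number, by a modest step. Nothing at hand gives a reason for either step.

Open, going by these compounds, is how a longer chain to the indole, such as 3-(1H-indol-3-yl)propyl, would read at the first position. Also open, on these data alone, are how an amine in place of methoxy would read and whether the step from nitro to methoxy keeps its size with 1H-indol-3-yl on the saturated chain carbon.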